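This account rests on a few compounds, and the source may have more. Where it says the series, first, only, none or still open, it means among the compounds named here.

In a functional assay on RS4-11 cells (Homo sapiens) for inhibition, read by CCK-8 assay, with a stated time of 48 h (on this read-out lower numbers stand for stronger inhibition and higher numbers for weaker inhibition), the measured compounds stand as follows.
Compound 1 `O=C(NCCNS(=O)(=O)c1ccc(-c2ccccc2Oc2ccc(O)c(O)c2)s1)Nc1cc(Cl)cc(Cl)c1` gives 4500 nM.
Compound 2 `O=C(NCCNS(=O)(=O)c1ccc(-c2ccccc2O[C@H]2CC[C@H](O)CC2)s1)Nc1cc(Cl)cc(Cl)c1` gives 14100 nM.
Compound 3 `O=C(NCCNS(=O)(=O)c1ccc(-c2ccccc2OCc2ccccc2)s1)Nc1cc(Cl)cc(Cl)c1` gives only a limit of the assay, > 20000 nM, namely (the limit of > 20000 nM in this assay, at which 1 of the 3 values shown sits).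

Where compound 3 stands is therefore known only as a limit: the step of an at least 4.4-fold higher number from compound 1 to compound 3 (0.64 log units; beyond the scatter) is beyond the scatter, as is a 3.1-fold higher number from compound 1 to compound 2 (0.50 log units; beyond the scatter), whereas an at least 1.4-fold higher number from compound 2 to compound 3 (0.15 log units; that floor lies within the scatter) has a floor that sits within it. Compound 4 `COc1ccc(NC(=O)NCCNS(=O)(=O)c2ccc(-c3ccccc3OCc3ccccc3)s2)cc1` differs from compound 3 by 4-methoxyphenyl in place of 3,5-dichlorophenyl on an amide-type nitrogen. None of the three measured steps touches this position; all of them concern the group on the ring oxygen, so they give no direction for this change. Among the compounds with values here, the step is expected to be a step that the limit leaves unreadable from compound 3 to compound 4, as no measured step points either way. Compound 4 is estimated at 25000 nM, within a range from 6000 nM to 100000 nM, with a fair chance that the assay again reports only a limit.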

Compound 4, half-maximal inhibitory concentration: > 20000 nM
Compound 4: no number, only a limit (the forecaster's own chance of this, stated with the estimate: 65%); the middle value lies beyond the limit too.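

In this assay, within the data shown here, compound 3 and compound 4 both give only a limit, so no step between them can be read: the limit of > 20000 nM in this assay, at which 2 of the 4 values shown sit.

From the compounds shown here alone, whether 4-methoxyphenyl or 3,5-dichlorophenyl on the amide-type nitrogen gives the stronger inhibition stays open.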